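The source may hold more compounds than are shown below. What is called first, only, known or untested is meant among the compounds shown, and "the series" means these compounds.

The measurements come from a functional assay on SW480 cells (Homo sapiens) for cytotoxicity, read by MTT assay, with a stated time of 24 h (on this read-out higher numbers stand for weaker inhibition and lower numbers for stronger inhibition), a cell-based test of how strongly each compound holds back cell growth. Compound 1, with structure `C=CC1=C(C(=O)NCc2ccccc2)C(c2ccc(OC)cc2)OC1`, gives 39500 nM in this assay. Compound 2 has the structure `C=CC1=C(C(=O)Nc2ccccc2)C(c2ccc(Cl)c(Cl)c2)OC1`. For compound 2 the assay reports only a limit, > 100000 nM, not a number. That limit is the limit of > 100000 nM in this assay, at which 1 of the 2 values shown sits. Compound 3, with structure `C=CC1=C(C(=O)Nc2ccccc2)C(c2ccc(OC)cc2)OC1`, has not yet been measured. It differs from compound 2 in one place: 4-methoxyphenyl in place of 3,4-dichlorophenyl on a saturated ring carbon. For the measured compounds named here, no measured pair shows this exact change, so the size of the step rests on expectation alone. The step expected here, an at least 1.6-fold lower number from compound 2 to compound 3 (0.22 log units; that floor lies within the scatter), points toward stronger inhibition but stays modest. Compound 3 is estimated to give 60000 nM in this assay, with a plausible range from 25000 nM to 150000 nM, and there remains a real chance that it too lands at the limit.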

Compound 3, half-maximal inhibitory concentration: > 100000 nM
Compound 3 gave a limit, no number; the forecaster's own chance of this, stated with the estimate: 35%; at least 1.6-fold (0.22 log units) between middle value and limit.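

For compound 3, this assay returns only a limit, > 100000 nM, and not a number. The change from 3,4-dichlorophenyl to 4-methoxyphenyl on this saturated ring carbon therefore cannot be sized, as compound 2 and compound 3 both stop at the same limit: the limit of > 100000 nM in this assay, at which 2 of the 3 values shown sit.

The amide side does give a readable result: with 4-methoxyphenyl held constant, phenyl in place of benzyl on the amide-type nitrogen gives an at least 2.5-fold higher number from compound 1 to compound 3 (0.40 log units; beyond the scatter), which means weaker inhibition, so 4-methoxyphenyl alone does not bring a measurable value with phenyl on that nitrogen.

As far as these compounds go, how 3,4-dichlorophenyl behaves with benzyl on the nitrogen remains open, so the effect of the swap on the saturated ring carbon is still unknown. From the compounds shown here alone, it is also open whether a longer chain, such as 2-phenylethyl, on that nitrogen would go with stronger or weaker inhibition than benzyl.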